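The source may hold more compounds than are shown below. What is called first, only, known or untested is meant among the compounds shown, and "the series" means these compounds.

Compound 2, `CC(=O)OCCO[C@H](CC=C(C)C)C1=CC(=O)c2c(O)ccc(O)c2C1=O`, gives 15500 nM in a functional assay on DU-145 cells (Homo sapiens) for cytotoxicity, read by MTT assay (a lower number here means a stronger inhibitor, a higher number a weaker inhibitor), the only plain number shown. Compound 1, `CC(C)=CC[C@@H](OC(=O)c1ccoc1)C1=CC(=O)c2c(O)ccc(O)c2C1=O`, reaches only the limit > 100000 nM, which is a bound of the assay rather than a number, as the limit of > 100000 nM in this assay, at which 1 of the 2 values shown sits, records. Among the measured compounds shown here, the one measured step, an at least 6.4-fold lower number from compound 1 to compound 2 (0.80 log units; beyond the scatter), bears on compound 3, `CCCCC(C)(O)CC(=O)O[C@H](CC=C(C)C)C1=CC(=O)c2c(O)ccc(O)c2C1=O`, which carries an ester again: (2-hydroxy-2-methylhexyl)carbonyl in place of 2-acetoxyethyl on an oxygen on a saturated carbon. Since a carbonyl-linked group on that oxygen came with the weaker limit, a move back toward a higher number is expected, a 2.6-fold higher number from compound 2 to compound 3 (0.41 log units; beyond the scatter), with a fair chance of another limit. Compound 3 is therefore estimated at 40000 nM, between 12000 nM and 130000 nM.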

Compound 3, half-maximal inhibitory concentration: 76500 nM
For compound 3 the middle estimate is 1.9-fold (0.28 log units) below the measured one; the range from low to high includes it.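

On the oxygen on a saturated carbon, a second carbonyl-linked group, (2-hydroxy-2-methylhexyl)carbonyl, also falls on the weaker side of 2-acetoxyethyl in this assay, with a 4.9-fold higher number from compound 2 to compound 3 (0.69 log units; beyond the scatter). Putting 2-hydroxy-2-methylhexyl in place of furan-3-yl on a carbonyl carbon gives an at least 1.3-fold lower number from compound 1 to compound 3 (0.11 log units; that floor lies within the scatter), so those two carbonyl-linked groups cannot be ordered. The value of compound 1 is a limit: the limit of > 100000 nM in this assay, at which 1 of the 3 values shown sits.

As far as these compounds go, it remains open whether an amine or a carboxylic acid at the end of a chain on this oxygen would bring the number lower than 2-acetoxyethyl does.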